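The source may hold more compounds than are shown below. What is called first, only, known or untested is meant among the compounds shown, and "the series" means these compounds.

Of the compounds shown here, three have a number so far. Compound 1 `C/C(=N\NC(=O)c1cc2ccccc2cc1O)c1ccc(N)cc1` gives 1100 nM in a functional assay on HEK293 cells for agonist activity at G-protein coupled receptor 39 (Homo sapiens), read by scintillation proximity assay and inositol phosphate accumulation, with a stated time of 75 min, in the presence of a further agent that is not named here; a lower number here means that less compound is needed, a higher number that more compound is needed for the effect. Compound 2 `CCCCCCCCOC1CC(=O)Nc2c1c(C)nn2-c1ncnc2nc[nH]c12` gives 8 nM in this assay, and compound 3 `C=CCN1c2c(n(C)c(=O)n(C)c2=O)NC1N/N=C/c1ccc(O)cc1O` gives 340 nM in this assay. Compound 2 thus stands lowest of the three; the nearest number is that of compound 3, the furthest that of compound 1, and both gaps lie beyond the usual scatter of repeated measurements. No two of these compounds differ in only one place, so no step between measured compounds can be drawn from them.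

Compound 4 `Cc1nn(-c2ncnc3nc[nH]c23)c2c1C(c1ccc(F)cc1Cl)CC(=O)N2` has not yet been measured. It differs from compound 2 in one place: 2-chloro-4-fluorophenyl in place of octyloxy on a saturated ring carbon. The chain that leaves has no ring and carries one hydrogen-bond acceptor, while the group that enters is an aromatic ring with no donor and no acceptor. The three measured compounds give no guide to how such an exchange on this ring carbon moves the number in this assay, so the expectation rests on compound 2 alone.

Compound 4 is expected to sit somewhat higher than compound 2, the estimated step being a 3.8-fold higher number from compound 2 to compound 4 (0.57 log units; beyond the scatter), a modest rise that may still fall within the scatter. The value of compound 4 in this assay is estimated at 30 nM, with a range from 5 nM to 200 nM.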

Compound 4, half-maximal effective concentration: 9 nM
Beside the measured number, compound 4's estimate is 3.3-fold (0.52 log units) above it; measured number inside the range.
By their numbers in this assay, from the lowest: compounds 2 and 4 (each within the scatter of the next); then compound 3; then compound 1.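

Exchanging octyloxy for 2-chloro-4-fluorophenyl on the saturated ring carbon gives a 1.1-fold higher number from compound 2 to compound 4 (0.05 log units; within the scatter) in this assay, so the two groups cannot be told apart by this read-out. This shows that, on the shared core, a long open chain with an oxygen is not needed at this position, since an aromatic ring of carbon only, with no hydrogen-bond acceptor, serves equally well here. It is a single exchange, however, so it marks out two groups that match at this ring carbon rather than a general tolerance, and nothing in the data shown explains why these two groups give matching numbers.

On these data alone, it remains open whether the match would hold for a shorter chain such as methoxy, for an unsubstituted phenyl, or for an amine or a carboxylic acid on the same ring carbon. It is also open how much the chlorine and the fluorine each contribute to the number of compound 4, as no compound shown carries only one of them.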